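Losing the chain hydroxy: from compound 3 to compound 4

A few compounds are considered here, and "the series" means these few. Any claim that something is new, unique, unknown or untested is made for them only; others in the source may bear on it.

Measured in a functional assay on HL-60 cells (Homo sapiens) for cytotoxicity, read by WST assay, with a stated time of 48 h; on this read-out lower numbers stand for stronger inhibition and higher numbers for weaker inhibition:
Compound 1 `COc1cc(C(c2ccc(O)c(OC)c2)[C@H](C)C(C)C)ccc1O`: 17000 nM
Compound 2 `COc1cc(C(c2ccc(O)c(OC)c2)[C@@H](C)C(C)C)ccc1O`: 20000 nM
Compound 3 `COc1cc(C(c2ccc(O)c(OC)c2)[C@@H](C)[C@H](C)CO)ccc1O`: > 100000 nM (a limit of the assay)

Compound 3 has no exact number, only the limit > 100000 nM. Compound 4 `CCCCC[C@H](C(C)C)C(c1ccc(O)c(OC)c1)c1ccc(O)c(OC)c1` differs from it as follows: 1-isopropylhexyl in place of 2-(hydroxymethyl)-1-methylpropyl on a saturated chain carbon bound to two aromatic carbons. Like compound 1 and compound 2, compound 4 has no hydroxy on this chain, so two steps bear on it: an at least 5.8-fold higher number from compound 1 to compound 3 (0.76 log units; beyond the scatter) and an at least 5.0-fold higher number from compound 2 to compound 3 (0.69 log units; beyond the scatter). Reversing them points to a lower number, of at least modest size. Going by the values given here, no measured compound carries the 1-isopropylhexyl chain, so the estimate remains uncertain. An estimated at least 10-fold lower number from compound 3 to compound 4 (1.00 log units; beyond the scatter) is therefore expected. For compound 4 the expected value is 10000 nM, with an estimated range of 3000 nM to 30000 nM.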

Compound 4, half-maximal inhibitory concentration: 9600 nM
Estimate against measurement, compound 4: 1.0-fold (0.02 log units) above; low and high end bracket the measured number.
By their numbers in this assay, from the lowest: compounds 4, 1 and 2 (each within the scatter of the next, the first and the last beyond it). At a limit, above all of these: compound 3.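

In this assay compound 3 stands only at a limit of the assay (> 100000 nM). The step to a chain without a hydroxy has only a bounded size (an at least 10-fold lower number from compound 3 to compound 4 (1.01 log units; beyond the scatter)). Against the 1,2-dimethylpropyl chain, the longer 1-isopropylhexyl chain gives only small steps (a 2.1-fold lower number from compound 2 to compound 4 (0.32 log units; beyond the scatter); a 1.8-fold lower number from compound 1 to compound 4 (0.25 log units; within the scatter)), so this position accepts a much longer chain without a hydroxy and keeps a measurable number. The compounds shown leave open whether a hydroxy on the 1-isopropylhexyl chain would again push the number up to the limit. They also leave open how an amine or a carboxylic acid on this chain would read.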